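The source may hold more compounds than are shown below. What is called first, only, known or untested is meant among the compounds shown, and "the series" means these compounds.

Compound 1 `CN(Cc1ccccc1)C(=O)c1ccc(-c2cc(C3=CC(=O)C=CC3=O)no2)s1` and compound 2 `COc1ccc(CN(C)C(=O)c2ccc(-c3cc(C4=CC(=O)C=CC4=O)no3)s2)cc1` share one core and differ in a single place. In a functional assay on A549 cells (Homo sapiens) for cytotoxicity, read by XTT assay, with a stated time of 72 h (on this read-out higher numbers stand for weaker inhibition and lower numbers for stronger inhibition), compound 1 returns > 30000 nM, which is a limit of the assay rather than a number. In this assay compound 2 likewise returns > 30000 nM, again a limit and not a measured number. The step from compound 1 to compound 2 (a step that the two limits leave unreadable from compound 1 to compound 2) therefore cannot be read, because of the limit of > 30000 nM in this assay, at which 2 of the 2 values shown sit. Compound 2 thus stands at that limit, with no measured number in this assay to place it against.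

Compound 3 `CN(Cc1ccc(F)cc1)C(=O)c1ccc(-c2cc(C3=CC(=O)C=CC3=O)no2)s1` differs from compound 2 by fluoro in place of methoxy on an aromatic carbon. Among the measured compounds shown here, the only measured step that bears on a change at this place is the one from compound 1 to compound 2, and it is unreadable; no change on this ring has yet produced a number in this assay. Compound 3 is therefore expected to remain at the limit, with a step that the limit leaves unreadable from compound 2 to compound 3 as the expected step. The estimate for compound 3 in this assay is 40000 nM, within a range from 15000 nM to 120000 nM.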

Compound 3, half-maximal inhibitory concentration: > 30000 nM
Compound 3 was reported as a limit; the forecaster's own chance of this, stated with the estimate: 85%; the middle value is on the limit's open side.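

Compound 3 returns > 30000 nM in this assay, which is a limit of the assay and not a number. No step among compound 1, compound 2 and compound 3 can therefore be read: the limit of > 30000 nM in this assay, at which 3 of the 3 values shown sit.

The compounds shown leave open whether any change on this aromatic ring can bring a measured number in this assay.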